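A Methyl Step at the Edge of a Permeability Limit

A few compounds are considered here, and "the series" means these few. Any claim that something is new, unique, unknown or untested is made for them only; others in the source may bear on it.

Of the compounds shown here, two have been read so far in an ADME assay on LLC-PK1 cells (Sus scrofa) for permeability; on this read-out higher numbers stand for higher permeability and lower numbers for lower permeability. Compound 1 `CN(C)c1ccc(-c2nc3ccc(F)nc3o2)cc1`, which carries a dimethylamino group, gives > 20 10^-6 cm/s, a limit of the assay and not a number. Compound 2 `CNc1ccc(-c2nc3ccc(F)nc3o2)cn1` gives > 20 10^-6 cm/s, which is likewise a limit and not a number. For the measured compounds named here, compound 2 therefore has no exact reading, and the whole series so far comes down to the limit of > 20 10^-6 cm/s in this assay, at which 2 of the 2 values shown sit.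

Compound 3 `CN(C)c1ccc(-c2nc3ccc(F)nc3o2)cn1` has not yet been measured. It differs from compound 2 by methyl in place of hydrogen on a nitrogen on an aromatic ring, or methylamino to dimethylamino. Going by the values given here, no measured pair shows the size of this change, so any forecast in this assay must lean on the two limits alone. Since compound 1 also has dimethylamino and gives > 20 10^-6 cm/s, compound 3 is expected to stay in the same region, quite possibly as another limit. The estimated step that the limit leaves unreadable from compound 2 to compound 3 is expected to stay within the usual scatter, with no clear direction. For compound 3 the expected value is 28 10^-6 cm/s, with an estimated range from 16 10^-6 cm/s to 50 10^-6 cm/s.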

Compound 3, apparent permeability: > 20 10^-6 cm/s
Compound 3: a limit, no number; the forecaster's own chance of this, stated with the estimate: 70%; the middle value lies beyond the limit too.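

In this assay, for the compounds shown here, compound 3 matches compound 2 in standing at a limit and not a number, so no step between compound 2 and compound 3 can be read: the limit of > 20 10^-6 cm/s in this assay, at which 3 of the 3 values shown sit.

The compounds shown leave open how far any of them lies past that limit, and whether methylamino to dimethylamino changes the reading at all.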